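The compounds below may be only part of what the source reports. "The series", "measured", "known", "first", "only" and "open" are said of these compounds alone.

Compound 1 `C/C(=C\CC/C(C)=C/CC[C@@H]1[C@@]2(C)CCC(=O)C(C)(C)[C@H]2CC[C@@]1(C)O)CC/C=C(\C)C(=O)OCc1cn(-c2ccc(C(F)(F)F)cc2)nn1` belongs to a small set of esters built on one shared core, each carrying a different group on a five-membered aromatic ring with three nitrogens. In a functional assay on MDA-MB-231 cells (Homo sapiens) for antiproliferative activity, read by MTT assay, with a stated time of 48 h (a lower number here means a stronger inhibitor, a higher number a weaker inhibitor), compound 1 gives > 150000 nM, which is a limit of the assay rather than a measured number. Compound 2 `C/C(=C\CC/C(C)=C/CC[C@@H]1[C@@]2(C)CCC(=O)C(C)(C)[C@H]2CC[C@@]1(C)O)CC/C=C(\C)C(=O)OCc1cn(C[C@@H]2O[C@H](n3ccc(=O)[nH]c3=O)C[C@H]2O)nn1` carries a sugar-like group instead and in this assay gives 26300 nM. Compound 1 therefore stands at the limit of > 150000 nM in this assay, at which 1 of the 2 values shown sits, so nothing more than that can be said of where it lies. Compound 3 `C/C(=C\CC/C(C)=C/CC[C@@H]1[C@@]2(C)CCC(=O)C(C)(C)[C@H]2CC[C@@]1(C)O)CC/C=C(\C)C(=O)OCc1cn(-c2cccc(C(F)(F)F)c2)nn1` differs from compound 1 only in where the trifluoromethyl sits on the phenyl: 3-(trifluoromethyl)phenyl in place of 4-(trifluoromethyl)phenyl on an aromatic nitrogen. For the measured compounds named here, because compound 1 sits at the limit of > 150000 nM in this assay, at which 1 of the 2 values shown sits, no measured step within the set shows how such a move affects potency. The change from compound 1 to compound 3 is expected to be small, an at least 1.2-fold lower number from compound 1 to compound 3 (0.09 log units; that floor lies within the scatter), with compound 3 expected to give about 120000 nM, likely between 40000 nM and 300000 nM.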

Compound 3, half-maximal inhibitory concentration: > 150000 nM
Compound 3 was reported as a limit; the forecaster's own chance of this, stated with the estimate: 60%; middle value at least 1.2-fold (0.09 log units) away from the limit.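

No step can be read between compound 1 and compound 3, because each is reported only as a limit, not a number: the limit of > 150000 nM in this assay, at which 2 of the 3 values shown sit. The compounds shown leave open whether 3-(trifluoromethyl)phenyl and 4-(trifluoromethyl)phenyl differ in potency at all.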